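The source may hold more compounds than are shown below. What is called first, only, known or untested is meant among the compounds shown, and "the series" means these compounds.

Measured so far:
- compound 1, `C#CCSc1nc(Nc2cccc(C(F)(F)F)c2)c(C#N)c(-c2ccccc2)n1`: 61100 nM
- compound 2, `COc1ccccc1Nc1nc(SCc2cn(Cc3ccccc3Cl)nn2)nc(-c2ccccc2)c1C#N`: 7860 nM
- compound 3, `Cc1ccc(Cn2cc(CSc3nc(Nc4ccccc4F)c(C#N)c(-c4ccccc4)n3)nn2)cc1`: 16000 nM

In a functional assay on B16-F10 cells (Mus musculus) for inhibition, read by MTT assay, with a stated time of 72 h (a higher number here means a weaker inhibitor, a lower number a stronger inhibitor), compound 2 gives the lowest of the three numbers. Compound 3 sits nearest to it, a step beyond the scatter, and compound 1 sits furthest away, so on these three numbers compound 2 is the most potent.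

The next compound is compound 4, `Cc1ccc(Nc2nc(SCc3cn(Cc4ccccc4Cl)nn3)nc(-c3ccccc3)c2C#N)cc1`, which keeps the shared core of compound 2 and differs from it only on the nitrogen on an aromatic ring: 4-methylphenyl in place of 2-methoxyphenyl on a nitrogen on an aromatic ring. For the measured compounds named here, no pair among the measured compounds isolates this change, so the step from compound 2 to compound 4 has no direct precedent. Compound 3, which also carries a different substituent on that nitrogen alongside a changed group on the other side of the core, gives the nearer of the two weaker values, which suggests that variation at this position moves the number only modestly.

The expected step of a 1.7-fold higher number from compound 2 to compound 4 (0.22 log units; within the scatter) is a small loss, close to the scatter. Compound 4 is therefore estimated at 13000 nM, with a range from 5000 nM to 35000 nM.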

Compound 4, half-maximal inhibitory concentration: 3390 nM
Beside the measured number, compound 4's estimate is 3.8-fold (0.58 log units) above it; the measured number lies below the stated range.
By their numbers in this assay, from the lowest: compound 4; then compound 2; then compound 3; then compound 1.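

For the compounds shown here, the change gives a 2.3-fold lower number from compound 2 to compound 4 (0.37 log units; beyond the scatter) in this assay and is the first direct reading at this nitrogen with the rest of the structure held constant. The aromatic group on this nitrogen therefore affects the number by a modest step beyond the scatter, and within this pair, the hydrogen-bond acceptor counted in 2-methoxyphenyl is not needed to retain activity. No measurement here bears on the cause of this step.

The methoxy-to-methyl swap and the shift in substitution position arrive together, so 2-methylphenyl and 4-methoxyphenyl on the same nitrogen would be needed to separate them. On these data alone, how a carboxylic acid or an amine on this aromatic ring would move the number also remains open.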